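The compounds below may be only part of what the source reports. "The series", "measured", "known", "first", "only" and "open" are said of these compounds alone.

Measured so far in a functional assay on OVCAR-8 cells (Homo sapiens) for antiproliferative activity; a higher number here means a weaker inhibitor, a lower number a stronger inhibitor:
- compound 1 `CNC(=O)C[C@@H]1C[C@@H](c2ccc(Cl)c(Cl)c2)[C@H](NC(=O)c2cc(-c3c(Cl)cnn3C)c(Cl)o2)CN1`: 1130 nM
- compound 2 `Cn1ncc(Cl)c1-c1cc(C(=O)N[C@@H]2CN[C@H](CCNS(C)(=O)=O)C[C@H]2c2ccc(F)c(F)c2)oc1Cl`: 1530 nM
- compound 3 `Cn1ncc(Cl)c1-c1cc(C(=O)N[C@@H]2CN[C@H](CC(O)CO)C[C@H]2c2ccc(F)c(F)c2)oc1Cl`: 690 nM

The value of compound 1 lies within the scatter of the values of both other compounds. Compound 4 `Cn1ncc(Cl)c1-c1cc(C(=O)N[C@@H]2CN[C@H](CCCO)C[C@H]2c2ccc(Cl)c(Cl)c2)oc1Cl` differs from compound 1 as follows: 2-hydroxyethyl in place of methylcarbamoyl on a saturated chain carbon bound to a saturated ring carbon. That is 2-hydroxyethyl in place of methylcarbamoyl on a saturated chain carbon bound to a saturated ring carbon. Among the compounds with values here, no measured step covers this exact swap. The nearest, at the same place, is modest: a 2.2-fold lower number from compound 2 to compound 3 (0.35 log units; beyond the scatter). A small change in this assay is therefore expected, with no clear direction: a 1.3-fold lower number from compound 1 to compound 4 (0.12 log units; within the scatter), not expected to exceed the scatter. Compound 4 is estimated at 850 nM, with an expected range of 350 nM to 2000 nM.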

Compound 4, half-maximal inhibitory concentration: 600 nM
Estimate against measurement, compound 4: 1.4-fold (0.15 log units) above; measured number inside the range.
By their numbers in this assay, from the lowest: compounds 4, 3, 1 and 2 (each within the scatter of the next, the first and the last beyond it).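

In this assay, 2-hydroxyethyl in place of methylcarbamoyl on a saturated chain carbon bound to a saturated ring carbon gives a 1.9-fold lower number from compound 1 to compound 4 (0.27 log units; within the scatter), so this swap removes the carbonyl-containing group without a change that can be told from scatter. The earlier step at this place, a 2.2-fold lower number from compound 2 to compound 3 (0.35 log units; beyond the scatter), involved different groups and does not show this. No available evidence accounts for the result.

Going by these compounds, whether a primary amine, a carboxylic acid or a longer chain ending in hydroxyl would be tolerated at this place remains open.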